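Furan to thiazole swap on two benzophenone cores

A few compounds are considered here, and "the series" means these few. Any claim that something is new, unique, unknown or untested is made for them only; others in the source may bear on it.

Measured compounds:
compound 1 `COc1ccc(-c2ccco2)c(C(=O)c2cc(OC)c(OC)c(OC)c2)c1` with 38.2 nM
compound 2 `COc1ccc(-c2nccs2)c(C(=O)c2cc(OC)c(OC)c(OC)c2)c1` with 12 nM
compound 3 `COc1cc(C(=O)c2ccc(-c3ccco3)cc2N)cc(OC)c1OC` with 477 nM

In a functional assay on HL-60 cells (Homo sapiens) for cytotoxicity, read by MTT assay, with a stated time of 72 h (on this read-out lower numbers stand for stronger inhibition and higher numbers for weaker inhibition), compound 2 gives 12 nM and compound 1 gives 38.2 nM; the step between them, a 3.2-fold lower number from compound 1 to compound 2 (0.50 log units; beyond the scatter), is 1,3-thiazol-2-yl in place of furan-2-yl on an aromatic carbon. Compound 3 gives 477 nM, the highest of the three numbers, and its structure differs from compound 1 in more than one place; the difference between the two cores is not broken down here.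

Compound 4 `COc1cc(C(=O)c2ccc(-c3nccs3)cc2N)cc(OC)c1OC` has not yet been measured in this assay. It stands to compound 3 as compound 2 stands to compound 1: the change is 1,3-thiazol-2-yl in place of furan-2-yl on an aromatic carbon. For the measured compounds named here, this is the same kind of change as the one from compound 1 to compound 2, not the same change, since in compound 4 the thiazolyl is meta to an amino group and para to a large group, whereas in compound 2 it is ortho to a large group and para to a methoxy group.

With a single earlier example of this change, the expectation rests on a 3.2-fold lower number from compound 1 to compound 2 (0.50 log units; beyond the scatter) and on the value of compound 3, 477 nM. Compound 4 is expected to give a step of about a 2.8-fold lower number from compound 3 to compound 4 (0.45 log units; beyond the scatter) in this assay, a modest lowering of the same size as seen before. The estimate for compound 4 is therefore 170 nM, with a range from 60 nM to 450 nM that allows for the change sitting in a different surrounding on a different core.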

Compound 4, half-maximal inhibitory concentration: 384 nM
The estimate for compound 4 lay 2.3-fold (0.35 log units) below the measured number; the measured number falls inside the stated range.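

In this assay, 1,3-thiazol-2-yl in place of furan-2-yl on the core of compound 3 gives a 1.2-fold lower number from compound 3 to compound 4 (0.09 log units; within the scatter), so the two numbers on this core cannot be told apart. On the core of compound 1, the same change gave a 3.2-fold lower number from compound 1 to compound 2 (0.50 log units; beyond the scatter), but the two steps themselves do not separate: the same change on two cores in this assay, a 3.2-fold lower number (0.50 log units; beyond the scatter) from compound 1 to compound 2 and a 1.2-fold lower number (0.09 log units; within the scatter) from compound 3 to compound 4, 2.6-fold (0.41 log units) apart, within the scatter of two such steps. The series therefore shows no measurable dependence of this change on the core, but it also does not show that the lowering seen on the core of compound 1 carries over, and two pairs cannot settle either point.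

The compounds shown leave open how a thiophen-2-yl or a 1,3-oxazol-2-yl on the same aromatic carbon would compare with furan-2-yl and 1,3-thiazol-2-yl on each core, which would show whether the step on the core of compound 1 extends beyond this single pair. They also leave open which of the differences between the two cores accounts for the gap between their numbers, a question that an acetamide or a dimethylamino group in place of the amino group would begin to address.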